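The source may report more compounds than this note shows. Statements on the series, on what has been measured and on what is new or still open speak of the compounds shown alone.

Compound 1, `O=C(Nc1ccccc1)c1c(NO)cc(-c2ccccc2)oc1=O`, gives 11600 nM in an ADME assay on Huh-7 cells (Homo sapiens) for cytotoxicity, read by a luciferase reporter and WST assay, with a stated time of 3 days; on this read-out higher numbers stand for lower toxicity in this test and lower numbers for higher toxicity in this test. Compound 2, `O=C(Nc1ccccc1)c1c(NO)cc(-c2ccc(F)cc2)oc1=O`, gives 10300 nM in this assay. Compound 3, `COC(=O)CNC(=O)c1c(NO)cc(-c2ccccc2)oc1=O`, reaches only the limit of this assay, recorded as > 20000 nM, so for compound 3 no number is known, only that it lies at this limit.

Between compound 1 and compound 2 the change is fluoro in place of hydrogen on an aromatic carbon, and it made a 1.1-fold lower number from compound 1 to compound 2 (0.05 log units; within the scatter). The cores of compound 1 and compound 3 differ by (methoxycarbonyl)methyl in place of phenyl on an amide-type nitrogen, which gave an at least 1.7-fold higher number from compound 1 to compound 3 (0.23 log units; that floor lies within the scatter).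

Compound 4, `COC(=O)CNC(=O)c1c(NO)cc(-c2ccc(F)cc2)oc1=O`, has not been measured in this assay. Among the measured compounds shown here, it differs from compound 3 by fluoro in place of hydrogen on an aromatic carbon, the same change as the one between compound 1 and compound 2, made at a place described in the same words. For compound 4 the expected step is a step that the limit leaves unreadable from compound 3 to compound 4, because compound 3 already sits at the limit of > 20000 nM in this assay, at which 1 of the 3 values shown sits, and the earlier step of this kind was a 1.1-fold lower number from compound 1 to compound 2 (0.05 log units; within the scatter), within the scatter. Compound 4 is therefore estimated at 22000 nM, with the expected range running from 11000 nM to 45000 nM, and it is expected that this assay will most likely again report only a limit for compound 4 rather than a number.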

Compound 4, half-maximal cytotoxic concentration: > 20000 nM
Compound 4: a limit, no number (the forecaster's own chance of this, stated with the estimate: 70%); the middle value does not contradict the limit.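

In this assay the change from hydrogen to fluoro cannot be read on the core carrying the (methoxycarbonyl)methyl group, because both of its compounds, compound 3 and compound 4, stand at a limit and not at a number: the limit of > 20000 nM in this assay, at which 2 of the 4 values shown sit.

The other change, (methoxycarbonyl)methyl in place of phenyl on the amide-type nitrogen, can be followed on the fluorinated core, where it gives an at least 1.9-fold higher number from compound 2 to compound 4 (0.28 log units; that floor lies within the scatter), and set beside its earlier counterpart it reads: the same change on two cores in this assay, an at least 1.7-fold higher number (0.23 log units; that floor lies within the scatter) from compound 1 to compound 3 and an at least 1.9-fold higher number (0.28 log units; that floor lies within the scatter) from compound 2 to compound 4; the limit leaves it open whether they differ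

So the two cores do not disagree about this change, but this does not show that the step has the same size on both, nor that it goes beyond the usual scatter of repeated measurements.

Going by these compounds, how far compound 3 and compound 4 lie past their limit stays open, and with it the true size of every step that ends at them. Also open, on these data alone, is whether an amine, a carboxylic acid or a longer chain on the amide-type nitrogen, or chloro in place of fluoro on the aromatic ring, would give a readable number in this assay.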